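From 3-nitrophenyl to 4-methylphenyl on a shared core

The source may hold more compounds than are shown below. What is called first, only, known or untested is meant among the compounds shown, and "the series" means these compounds.

compound 1 `C[C@H]1CC[C@@H]2[C@@H](OC(=O)[C@]23CC(c2ccc(Cl)cc2)=NO3)[C@]2(C)C(=O)C=C[C@@]12O` – 51000 nM
compound 2 `C[C@H]1CC[C@@H]2[C@@H](OC(=O)[C@]23CC(c2cccc([N+](=O)[O-])c2)=NO3)[C@]2(C)C(=O)C=C[C@@]12O` – 49000 nM

In a functional assay on SW-620 cells (Homo sapiens) for cytotoxicity, read by sulforhodamine B assay, with a stated time of 48 h (a higher number here means a weaker inhibitor, a lower number a stronger inhibitor), compound 2 gives 49000 nM and stands within the scatter of compound 1, so neither can be ranked ahead of the other. Still unmeasured is compound 3 `Cc1ccc(C2=NO[C@]3(C2)C(=O)O[C@@H]2[C@H]3CC[C@H](C)[C@]3(O)C=CC(=O)[C@@]23C)cc1` which keeps the shared core and departs from compound 2 at a single place. The difference is 4-methylphenyl in place of 3-nitrophenyl on a carbon with a double bond to nitrogen and amounts to 4-methylphenyl in place of 3-nitrophenyl on a carbon with a double bond to nitrogen.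

Going by the values given here, one measured step bears on that carbon. It is a 1.0-fold lower number from compound 1 to compound 2 (0.02 log units; within the scatter) and it exchanged 4-chlorophenyl for 3-nitrophenyl without moving the value beyond the scatter. Among the compounds with values here, no compound carrying 4-methylphenyl has been measured, and a single step is slender evidence. Even so, no change beyond the scatter is expected in this assay for this exchange. The estimate amounts to an expected 1.0-fold higher number from compound 2 to compound 3 (0.01 log units; within the scatter) and nothing larger is anticipated. Compound 3 is expected at about 50000 nM with an estimated range from 25000 nM to 100000 nM as its likely span.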

Compound 3, half-maximal inhibitory concentration: 2500 nM
Estimate against measurement, compound 3: 20-fold (1.30 log units) above, outside the stated range (below it).
By their numbers in this assay, from the lowest: compound 3; then compounds 2 and 1 (each within the scatter of the next).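

In this assay the group on the carbon with a double bond to nitrogen proves able to move the value a long way: 4-methylphenyl in place of 3-nitrophenyl gives a 20-fold lower number from compound 2 to compound 3 (1.29 log units; beyond the scatter) and methyl in place of chloro on an aromatic carbon gives a 20-fold lower number from compound 1 to compound 3 (1.31 log units; beyond the scatter) on the same shared core. The earlier pair had shown only that 4-chlorophenyl and 3-nitrophenyl stand within the scatter of each other, whereas compound 3 now stands apart from both with steps beyond the scatter, which makes it the strongest inhibitor of the three in this assay. Nothing at hand says why 4-methylphenyl separates from the other two groups.

Going by these compounds alone, with only three groups at this position, it remains open whether the methyl group itself carries the step or whether unsubstituted phenyl would give a similar value. On these data alone, whether 4-ethylphenyl, with a longer chain, or 4-methoxyphenyl would follow compound 3 or stay with compound 1 and compound 2 also remains open, as does whether the step would hold in any other cell line.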